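The source may hold more compounds than are shown below. What is called first, only, known or untested is meant among the compounds shown, and "the series" means these compounds.

In a functional assay on HT-29 cells (Homo sapiens) for antiproliferative activity, read by MTT assay, with a stated time of 72 h (on this read-out lower numbers stand for stronger inhibition and higher numbers for weaker inhibition), compound 1 `C=CC(=O)Nc1nc(-c2ccccc2)cs1` gives 6600 nM and compound 2 `C=CC(=O)Nc1nc(-c2ccccc2Cl)cs1` gives 10200 nM while compound 3 `C=CC(=O)Nc1nc(-c2ccccc2)c(C(=O)OCC)s1` gives 18000 nM as its reading. Nothing measured lies beyond the scatter under compound 1: the chloro step is a 1.5-fold higher number from compound 1 to compound 2 (0.19 log units; within the scatter) and the ethoxycarbonyl step is a 2.7-fold higher number from compound 1 to compound 3 (0.44 log units; beyond the scatter) on the same core. Compound 4 `C=CC(=O)N(CC(=O)NC1COC1)c1nc(-c2ccccc2)cs1` differs from compound 1 by a group of 8 heavy atoms (5 carbon, 1 nitrogen, 2 oxygen; one four-membered non-aromatic ring with 1 hetero atom) in place of a hydrogen atom, on an amide-type nitrogen on an amide-type nitrogen. Neither measured step falls on that nitrogen, so both guide only loosely. Going by compound 3 at 18000 nM as the only step beyond the scatter, a modest rise in the number is expected in this assay with wide uncertainty. The expected step is a 1.8-fold higher number from compound 1 to compound 4 (0.26 log units; within the scatter) by this estimate. Compound 4 is estimated at 12000 nM in a range of 3500 nM to 40000 nM for this read-out.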

Compound 4, half-maximal inhibitory concentration: > 30000 nM
Compound 4: no number, only a limit (the forecaster's own chance of this, stated with the estimate: 15%); at least 2.5-fold (0.39 log units) between middle value and limit.
By their numbers in this assay, from the lowest: compounds 1, 2 and 3 (each within the scatter of the next, the first and the last beyond it). At a limit, above all of these: compound 4.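

The earlier steps shown here fell on aromatic carbons; compound 4 carries its change on the amide-type nitrogen, and in this assay replacing the amide hydrogen with this group of 8 heavy atoms gives an at least 4.5-fold higher number from compound 1 to compound 4 (0.65 log units; beyond the scatter). So a change on this nitrogen can raise the number beyond the scatter, with only a lower bound on the size of that rise. Compound 4 has no number, only a limit of the assay: the limit of > 30000 nM in this assay, at which 1 of the 4 values shown sits.

Going by these compounds, it stays open whether the rise follows from replacing the amide hydrogen at all or from this particular group. A simple methyl or a carboxylic acid on that nitrogen would separate those two readings.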